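A few compounds are considered here, and "the series" means these few. Any claim that something is new, unique, unknown or untested is made for them only; others in the source may bear on it.

Measured compounds:
- compound 1, `CC(C)(C)C(=O)N1CCC(NCC[S+]([O-])C(c2ccc(F)cc2)c2ccc(F)cc2)CC1`: 10200 nM in an assay on membranes from striatum (strain Sprague-Dawley) for displacement of a labelled ligand from sodium-dependent dopamine transporter (Rattus norvegicus), read by scintillation counting, with a stated time of 120 min; on this read-out lower numbers stand for stronger inhibition and higher numbers for weaker inhibition
- compound 2, `CC(C)(C)CN1CCC(NCC[S+]([O-])C(c2ccc(F)cc2)c2ccc(F)cc2)CC1`: 431 nM in this assay

Going by the values given here, of these two numbers, compound 2 has the lowest, and its only neighbour is compound 1, reached by the single measured step of a 24-fold lower number from compound 1 to compound 2 (1.37 log units; beyond the scatter). That step exchanged a (tert-butyl)carbonyl group for neopentyl on the amine nitrogen in the ring.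

Compound 3, `O=C(c1ccccc1F)N1CCC(NCC[S+]([O-])C(c2ccc(F)cc2)c2ccc(F)cc2)CC1`, is not yet measured. Its change from compound 2 is (2-fluorophenyl)carbonyl in place of neopentyl on an amine nitrogen in a ring. This step runs in the opposite sense to the measured one: a carbonyl-bearing group returns to the same ring nitrogen, although the part beyond the carbonyl is now a 2-fluorophenyl ring rather than tert-butyl. Because the measured step of a 24-fold lower number from compound 1 to compound 2 (1.37 log units; beyond the scatter) was large, a large rise in the number is expected for compound 3, a 12-fold higher number from compound 2 to compound 3 (1.06 log units; beyond the scatter). Compound 3 is therefore estimated at 5000 nM, with a range from 1500 nM to 20000 nM.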

Compound 3, inhibition constant: 604 nM
Beside the measured number, compound 3's estimate is 8.3-fold (0.92 log units) above it; the measured number lies below the stated range.
By their numbers in this assay, from the lowest: compounds 2 and 3 (each within the scatter of the next); then compound 1.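

The carbonyl on the ring nitrogen does not by itself bring the weak binding of compound 1: putting 2-fluorophenyl in place of tert-butyl on the carbonyl carbon gives a large change (a 17-fold lower number from compound 1 to compound 3 (1.23 log units; beyond the scatter)). In this assay, neopentyl and (2-fluorophenyl)carbonyl on this nitrogen cannot be told apart (a 1.4-fold higher number from compound 2 to compound 3 (0.15 log units; within the scatter)), even though only the second holds a ring and a hydrogen-bond acceptor. No evidence at hand explains why the group on the carbonyl carbon matters so much.

On these data alone, it remains open whether the fluorine contributes, since a plain phenyl on the carbonyl carbon would be needed to separate it from the ring. Also open, as far as these compounds go, is how a benzyl group on the same nitrogen, with no carbonyl, would compare with compound 3.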